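Swapping the Aryl Group on a Sulfonyl Sulfur

This account rests on a few compounds, and the source may have more. Where it says the series, first, only, none or still open, it means among the compounds named here.

In a functional assay on DU-145 cells (Homo sapiens) for antiproliferative activity, read by propidium iodide staining, with a stated time of 96 h (on this read-out lower numbers stand for stronger inhibition and higher numbers for weaker inhibition), compound 1 (`CC(O)(CSc1cccc(C(F)(F)F)c1)C(=O)Nc1cccc(S(F)(F)(F)(F)F)c1`) gives 19100 nM, and compound 2 (`CC(O)(CS(=O)(=O)c1ccc(F)cc1)C(=O)Nc1ccc(S(F)(F)(F)(F)F)cc1`) gives 27700 nM. Among the measured compounds shown here, these two numbers lie within the usual scatter of each other, so compound 2 cannot be ranked apart from the only other measured compound. For the measured compounds named here, the two differ in more than one place, which means no measured step yet shows the effect of a single change.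

Compound 3 (`CC(O)(CS(=O)(=O)c1ccccc1OC(F)(F)F)C(=O)Nc1ccc(S(F)(F)(F)(F)F)cc1`) differs from compound 2 in one place, with 2-(trifluoromethoxy)phenyl in place of 4-fluorophenyl on a sulfonyl sulfur. Compound 1 at 19100 nM and compound 2 at 27700 nM stay within the scatter despite their several differences, so a single swap seems unlikely to move the number far. No step beyond the scatter is expected in this assay, in either direction. The estimated change is a 1.4-fold lower number from compound 2 to compound 3 (0.14 log units; within the scatter). For compound 3 the expected value is 20000 nM, with an estimated range from 8000 nM to 45000 nM.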

Compound 3, half-maximal inhibitory concentration: 19500 nM
Estimate against measurement, compound 3: 1.0-fold (0.01 log units) above; low and high end bracket the measured number.
By their numbers in this assay, from the lowest: compounds 1, 3 and 2 (each within the scatter of the next).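

The set now holds its first change in one place: in this assay, putting 2-(trifluoromethoxy)phenyl in place of 4-fluorophenyl on a sulfonyl sulfur comes with a 1.4-fold lower number from compound 2 to compound 3 (0.15 log units; within the scatter). The read-out therefore shows no measurable response to this swap, even though the entering group has 11 heavy atoms and 1 hydrogen-bond acceptor, while the leaving group has 7 heavy atoms and 0 hydrogen-bond acceptors. No measured evidence here bears on why the number holds steady.

On these data alone, both groups compared on this sulfur are fluorine-bearing phenyl rings, so it remains open whether a different kind of group, such as a butyl chain or a pyridine ring, would give a step beyond the scatter. As far as these compounds go, the role of the sulfonyl group itself also remains open: compound 1 carries a plain sulfur but differs from compound 2 and compound 3 in more than one place, so its value cannot be read as the effect of that one feature.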